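Cyclohexyl in place of cyclobutylmethyl on the ether oxygen

The source may hold more compounds than are shown below. What is called first, only, known or untested is meant among the compounds shown, and "the series" means these compounds.

Measured in an assay on cells with melanin-concentrating hormone receptor 1 (Homo sapiens) as the target, read by radioligand binding; a higher number here means a weaker inhibitor, a lower number a stronger inhibitor:
compound 1 `Nc1ccc2cccc(OCC3CCCO3)c2n1` gives > 2000 nM, which is a limit of the assay and not a number.
compound 2 `CC(C)C(C)Oc1cccc2ccc(N)nc12` gives 199 nM.
compound 3 `Nc1ccc2cccc(OCC3CCC3)c2n1` gives 432 nM.

Compound 3 holds the higher of the two numbers; the step of a 2.2-fold higher number from compound 2 to compound 3 (0.34 log units; beyond the scatter) is modest, while compound 1 sits at a limit (the limit of > 2000 nM in this assay, at which 1 of the 3 values shown sits). Compound 4 `Nc1ccc2cccc(OC3CCCCC3)c2n1` differs from compound 3 by cyclohexyl in place of cyclobutylmethyl on an oxygen on an aromatic ring. Among the measured compounds shown here, two steps bear on this. The steps of an at least 4.6-fold lower number from compound 1 to compound 3 (0.66 log units; beyond the scatter) and an at least 10-fold lower number from compound 1 to compound 2 (1.00 log units; beyond the scatter) start from the limit, so their size is known only as a floor. The step of a 2.2-fold higher number from compound 2 to compound 3 (0.34 log units; beyond the scatter) shows that 1,2-dimethylpropyl gave a lower number than cyclobutylmethyl. A modest fall is therefore expected for compound 4, a 2.7-fold lower number from compound 3 to compound 4 (0.43 log units; beyond the scatter). Compound 4 is estimated at 160 nM, with a range from 45 nM to 600 nM.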

Compound 4, half-maximal inhibitory concentration: 361 nM
For compound 4 the middle estimate is 2.3-fold (0.35 log units) below the measured one; measured number inside the range.
By their numbers in this assay, from the lowest: compounds 2, 4 and 3 (each within the scatter of the next, the first and the last beyond it). At a limit, above all of these: compound 1.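

Swapping cyclobutylmethyl for cyclohexyl on the oxygen changes little in this assay: the step is a 1.2-fold lower number from compound 3 to compound 4 (0.08 log units; within the scatter), so the ring with one more carbon, set directly on the oxygen, does as well as the smaller one. Cyclohexyl also stays close to the branched 1,2-dimethylpropyl, with a 1.8-fold higher number from compound 2 to compound 4 (0.26 log units; within the scatter). Against (oxolan-2-yl)methyl the step is an at least 5.5-fold lower number from compound 1 to compound 4 (0.74 log units; beyond the scatter), which is only a floor, as it starts from a limit of the assay and not a number: the limit of > 2000 nM in this assay, at which 1 of the 4 values shown sits.

As far as these compounds go, whether an amine or a hydroxyl on the cyclohexyl ring would hold this level remains open. So does the effect of a longer straight chain on the oxygen.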